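This account rests on a few compounds, and the source may have more. Where it says the series, first, only, none or still open, it means among the compounds named here.

In a functional assay on NCI/ADR cells (Homo sapiens) for cytotoxicity, read by sulforhodamine B assay (a lower number here means a stronger inhibitor of growth, a higher number a weaker inhibitor of growth), three compounds have values so far:

Compound 1 `CC1=CC[C@@H]([C@@](C)(O)CCCC(C)(C)NC(=S)N/N=C\c2ccccc2)CC1`: 23800 nM
Compound 2 `CC1=CC[C@@H]([C@@](C)(O)CCCC(C)(C)NC(=S)N/N=C\c2ccc(C)cc2)CC1`: 30500 nM
Compound 3 `CC1=CC[C@@H]([C@@](C)(O)CCCC(C)(C)NC(=S)N/N=C\c2ccccc2Cl)CC1`: > 100000 nM (a limit, not a number)

Compound 3 stands at the limit of > 100000 nM in this assay, at which 1 of the 3 values shown sits, and so carries a limit rather than a number. Compound 4 `CC1=CC[C@@H]([C@@](C)(O)CCCC(C)(C)NC(=S)N/N=C\c2cccc(Cl)c2)CC1` has the same atoms as compound 3, joined differently. The difference is 3-chlorophenyl in place of 2-chlorophenyl on a carbon with a double bond to nitrogen and the rest of the molecule stays as it was.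

Among the measured compounds shown here, no measured step moves a chloro group around the ring, so the evidence is indirect. Two steps show what came with 2-chlorophenyl: an at least 4.2-fold higher number from compound 1 to compound 3 (0.62 log units; beyond the scatter) and an at least 3.2-fold higher number from compound 2 to compound 3 (0.51 log units; beyond the scatter) are both beyond the scatter, though each is known only as a minimum. A third step, a 1.3-fold higher number from compound 1 to compound 2 (0.11 log units; within the scatter), shows that 4-methylphenyl made no difference beyond the scatter.

Going by these compounds, whether the effect of 2-chlorophenyl carries over to 3-chlorophenyl is unknown, so a result nearer compound 1 and compound 2 seems likely, with a further limit still possible. The expected change is an at least 2.5-fold lower number from compound 3 to compound 4 (0.39 log units; beyond the scatter) and it points to a lower number, of uncertain size. Compound 4 is expected at 40000 nM with an estimated range from 15000 nM to 100000 nM in this assay.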

Compound 4, concentration for total growth inhibition: 31900 nM
Beside the measured number, compound 4's estimate is 1.3-fold (0.10 log units) above it; low and high end bracket the measured number.
By their numbers in this assay, from the lowest: compounds 1, 2 and 4 (each within the scatter of the next). At a limit, above all of these: compound 3.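

In this assay, the place of the chloro group on the ring matters for these compounds: 3-chlorophenyl in place of 2-chlorophenyl gives an at least 3.1-fold lower number from compound 3 to compound 4 (0.49 log units; beyond the scatter), a step known only as a minimum. Compound 3 itself carries a limit, not a number: the limit of > 100000 nM in this assay, at which 1 of the 4 values shown sits.

A chloro group on the ring does not by itself go with a weaker result: chloro in place of hydrogen gives a 1.3-fold higher number from compound 1 to compound 4 (0.13 log units; within the scatter), and 3-chlorophenyl in place of 4-methylphenyl gives a 1.0-fold higher number from compound 2 to compound 4 (0.02 log units; within the scatter), so among the compounds shown only 2-chlorophenyl stands apart.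

The compounds shown leave open why 2-chlorophenyl behaves differently, and whether a bromo or a methoxy group in place of the chloro of 2-chlorophenyl would give a limit like that of compound 3 or a number like those of the other three compounds. They also leave open whether a carboxylic acid or an amine on the phenyl ring would move the number beyond the scatter of compound 1, compound 2 and compound 4.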